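The compounds below may be only part of what the source reports. "The series", "measured", "known", "first", "only" and "open" are said of these compounds alone.

Three compounds share one core and differ only in the group carried by the chain on the ring amine. Compound 1 `COc1cc(N)c(Cl)cc1C(=O)N[C@H]1CCN(CC2CCN(C(=S)C(C)C)CC2)C[C@H]1OC` gives in an assay on COS-7 cells for displacement of a labelled ligand from 5-hydroxytryptamine receptor 4 (Homo sapiens), read by scintillation counting, with a stated time of 30 min (on this read-out higher numbers stand for weaker inhibition and lower numbers for stronger inhibition), a value of 155 nM. Compound 2 `COc1cc(N)c(Cl)cc1C(=O)N[C@H]1CCN(CC2CCN(C(C)=O)CC2)C[C@H]1OC` gives in this assay 592 nM. Compound 3 `CCC(=S)N1CCC(CN2CC[C@H](NC(=O)c3cc(Cl)c(N)cc3OC)[C@H](OC)C2)CC1` gives in this assay 593 nM, the highest of the three numbers; the step of a 3.8-fold higher number from compound 1 to compound 3 (0.58 log units; beyond the scatter) is beyond the scatter, while the step of a 1.0-fold higher number from compound 2 to compound 3 (0.00 log units; within the scatter) is within it, so compound 2 and compound 3 cannot be told apart.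

Compound 4 `COc1cc(N)c(Cl)cc1C(=O)N[C@H]1CCN(CCCn2cccc2)C[C@H]1OC` departs from compound 3 by a larger change: a group of 7 heavy atoms (6 carbon, 1 nitrogen; one five-membered aromatic ring with 1 hetero atom) in place of a group of 10 heavy atoms (8 carbon, 1 nitrogen, 1 sulfur; one six-membered non-aromatic ring with 1 hetero atom), on a saturated chain carbon bound to an amine nitrogen in a ring. Among the compounds with values here, none of the measured steps bears directly on this exchange; all three of them (a 3.8-fold higher number from compound 1 to compound 2 (0.58 log units; beyond the scatter), a 3.8-fold higher number from compound 1 to compound 3 (0.58 log units; beyond the scatter), a 1.0-fold higher number from compound 2 to compound 3 (0.00 log units; within the scatter)) alter only the substituent on the ring nitrogen that compound 4 loses entirely, and they were modest at most. With nothing closer to lean on, the step of a 1.0-fold higher number from compound 3 to compound 4 (0.01 log units; within the scatter) is expected to stay small, but with wide uncertainty. Compound 4 is therefore estimated at 600 nM in this assay, in a range from 120 nM to 3000 nM.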

Compound 4, half-maximal inhibitory concentration: 648 nM
Estimate against measurement, compound 4: 1.1-fold (0.03 log units) below, within the range that was stated.
By their numbers in this assay, from the lowest: compound 1; then compounds 2, 3 and 4 (each within the scatter of the next).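

The earlier compounds shown here changed only the group on the nitrogen of the six-membered non-aromatic ring, whereas compound 4 shows that in this assay the whole ring-bearing group can give way to 2-(1H-pyrrol-1-yl)ethyl, with a 1.1-fold higher number from compound 3 to compound 4 (0.04 log units; within the scatter) and a 1.1-fold higher number from compound 2 to compound 4 (0.04 log units; within the scatter) both within the scatter. Only against compound 1 does the exchange give a step beyond the scatter, with a 4.2-fold higher number from compound 1 to compound 4 (0.62 log units; beyond the scatter) setting compound 1 apart from the other three compounds. No measurement shown here accounts for these results.

The compounds shown leave open how much of the value of compound 4 depends on its five-membered aromatic ring and how much on the chain that carries it. A phenyl ring or a dimethylamino group on the same chain, or a longer chain bearing the same five-membered aromatic ring, would address that question.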